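Ring configuration and acid stability at the limit

A few compounds are considered here, and "the series" means these few. Any claim that something is new, unique, unknown or untested is made for them only; others in the source may bear on it.

Compound 1 `O=C(O)[C@H](CO)NC(=O)[C@H]1C[C@H](O)CN1`: > 12 h, a limit
Compound 2 `O=C(O)[C@@H](CO)NC(=O)[C@H]1C[C@@H](O)CN1`: > 12 h, a limit
Compound 3 `O=C(O)[C@@H](CO)NC(=O)[C@H]1C[C@H](O)CN1`: > 12 h, a limit

In a physicochemical assay for metabolic stability, read by HPLC, with a stated time of 12 h, at pH 1.2 (a lower number here means that the compound disappears faster, a higher number that the compound lasts longer), compound 3 gives > 12 h, which is a limit and not a number. Compounds 1 and 2 sit at that same limit. The change to compound 4 `O=C(N[C@H](CO)C(=O)O)[C@@H]1C[C@@H](O)CN1` is one of configuration only: the two compounds have the same atoms and bonds and differ only in configuration as drawn: 2 of 3 stereo elements differ; a stereocentre at a saturated ring carbon is drawn R in compound 3 and S in compound 4; a stereocentre at a saturated ring carbon is drawn S in compound 3 and R in compound 4. The measured steps that bear on it are a step that the two limits leave unreadable from compound 1 to compound 3, a step that the two limits leave unreadable from compound 2 to compound 3 and a step that the two limits leave unreadable from compound 1 to compound 2, so none of them offers a size to carry over. No step beyond the scatter is expected in this assay, in either direction. The estimated step is a step that the limit leaves unreadable from compound 3 to compound 4. The half-life expected for compound 4 is 20 h, with an estimated range from 12 h to 50 h.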

Compound 4, half-life: > 12 h
Compound 4 was reported as a limit; the forecaster's own chance of this, stated with the estimate: 90%; the middle value lies beyond the limit too.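

Compound 4 gives > 12 h in this assay, which is a limit. For the compounds shown here, no step from compound 1, compound 2 or compound 3 to compound 4 can be read, because all four sit there: the limit of > 12 h in this assay, at which 4 of the 4 values shown sit. Going by these compounds, whether configuration changes the half-life at all stays open.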